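The compounds below may be only part of what the source reports. "The series", "measured", "known", "first", "only" and "open" are said of these compounds alone.

Measured so far:
- compound 1, `Cc1cc(C(=O)Nc2ccccn2)nn1Cc1cc(Cl)ccc1OCc1ccccc1` — in a physicochemical assay for lipophilicity, at pH 7.4 (a lower number here means a more polar compound, a higher number a more lipophilic compound), compound 1 gives > 3.7
- compound 2, `Cc1cc(NC(=O)C2CCCC2)nn1Cc1cc(Cl)ccc1OCc1ccccc1` — in this assay compound 2 gives 3.5

The value for compound 1 is a limit of this assay, not a number. Compound 2 therefore stands on the only number shown, and the one measured step, a number at least 0.20 log units lower from compound 1 to compound 2 (that floor lies within the scatter), comes from putting (cyclopentylcarbonyl)amino in place of (pyridin-2-yl)carbamoyl on an aromatic carbon. The evidence for it rests on (the limit of > 3.7 in this assay, at which 1 of the 2 values shown sits).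

Compound 3, `Cc1cc(NC(=O)c2c(F)cccc2F)nn1Cc1cc(Cl)ccc1OCc1ccccc1`, has not yet been measured. It differs from compound 2 by 2,6-difluorophenyl in place of cyclopentyl on a carbonyl carbon. Going by the values given here, no measured step alters the group on the carbonyl carbon of compound 2, so the step from compound 1 to compound 2 bears on it only loosely: it shows that changing the amide side of the shared core moves this assay by an amount that is itself small. On that basis compound 3 is expected to move by a number 0.30 log units higher from compound 2 to compound 3 (within the scatter), upward, with a fair chance of reaching the limit again. Compound 3 is estimated at 3.8, within a range from 3.3 to 4.3.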

Compound 3, distribution coefficient: > 3.7
Compound 3 was reported as a limit; the forecaster's own chance of this, stated with the estimate: 50%; the middle value is on the limit's open side.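

This is the first change shown on the carbonyl carbon of compound 2, and in this assay putting 2,6-difluorophenyl in place of cyclopentyl gives a number at least 0.20 log units higher from compound 2 to compound 3 (that floor lies within the scatter). Compound 3 gives > 3.7, which is a limit of the assay and not a number. The change therefore has a readable direction but no readable size, its floor does not clear the scatter, and the step between compound 1 and compound 3 cannot be read at all, because both of its ends are limits: the limit of > 3.7 in this assay, at which 2 of the 3 values shown sit.

Compound 2, at 3.5, remains the only compound with a number, so the compounds shown leave open whether an amine or a carboxylic acid on the same carbonyl carbon would bring the reading clearly down from there. From the compounds shown here alone, it is also open how much of the step belongs to the aromatic ring and how much to the two fluorines, a question that a plain phenyl on that carbon could help to separate.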